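Adding a Methoxy Group to a Shared Core

A few compounds are considered here, and "the series" means these few. Any claim that something is new, unique, unknown or untested is made for them only; others in the source may bear on it.

Of the compounds shown here, three have been measured in a functional assay on MDA-MB-435 cells (Homo sapiens) for inhibition, read by sulforhodamine B assay, with a stated time of 48 h; on this read-out lower numbers stand for higher toxicity in this test and higher numbers for lower toxicity in this test. Compound 1 `COc1cc(-c2cc(/C=C/C(=O)c3ccc(N)cc3)[nH]n2)cc(OC)c1OC` gives 6200 nM in this assay. Compound 2 `COc1ccc(C(=O)/C=C/c2cc(-c3cc(OC)c(OC)c(OC)c3)n[nH]2)cc1OC` gives 5520 nM in this assay, and compound 3 `COc1ccc(-c2cc(/C=C/C(=O)c3ccc(N)cc3)[nH]n2)cc1OC` gives 40800 nM in this assay.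

Compound 3 and compound 1 differ in a single place: methoxy in place of hydrogen on an aromatic carbon. That change produced a 6.6-fold lower number from compound 3 to compound 1 (0.82 log units; beyond the scatter). Replacing the 4-aminophenyl on the carbonyl carbon with 3,4-dimethoxyphenyl gave a 1.1-fold lower number from compound 1 to compound 2 (0.05 log units; within the scatter), so these two compounds cannot be ordered against each other. The difference between the cores of compound 2 and compound 3 is not broken down here; their values show compound 3 with the clearly higher number of the two.

Compound 4 `COc1cc(C(=O)/C=C/c2cc(-c3cc(OC)c(OC)c(OC)c3)n[nH]2)cc(OC)c1OC` has not yet been measured in this assay. It relates to compound 2 as compound 1 relates to compound 3: methoxy in place of hydrogen on an aromatic carbon. The surroundings of the changed position are the same in both pairs, so this is the same change made a second time. Because the earlier instance gave a 6.6-fold lower number from compound 3 to compound 1 (0.82 log units; beyond the scatter), compound 4 is expected to show a 3.7-fold lower number from compound 2 to compound 4 (0.57 log units; beyond the scatter) in this assay, a step in the same direction but judged somewhat smaller, since compound 2 already stands at the lower end of the measured numbers. Compound 4 is therefore estimated at 1500 nM, within a range from 500 nM to 6000 nM.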

Compound 4, concentration lethal to 50% of the cells: 5820 nM
Beside the measured number, compound 4's estimate is 3.9-fold (0.59 log units) below it; the measured number falls inside the stated range.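

On the core of compound 2, methoxy in place of hydrogen on an aromatic carbon gave a 1.1-fold higher number from compound 2 to compound 4 (0.02 log units; within the scatter) in this assay, so the two compounds cannot be ordered against each other. The change therefore did not carry over from one core to the other with a step of the same size: the same change on two cores in this assay, a 6.6-fold lower number (0.82 log units; beyond the scatter) from compound 3 to compound 1 and a 1.1-fold higher number (0.02 log units; within the scatter) from compound 2 to compound 4, 6.9-fold (0.84 log units) apart, beyond the scatter of two such steps. This shows that, in this series, the step seen on one core cannot be taken over as it stands to another, but two pairs do not show what in the cores sets the results apart, nor how the same change would behave on any further core.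

The compounds shown leave open whether a different group in place of that hydrogen, such as a hydroxy group, a fluorine atom, an ethoxy group or a longer alkoxy chain, would move the number on the core of compound 2 or on that of compound 3. They also leave open whether a carboxylic acid or a dimethylamino group in place of the amine of the 4-aminophenyl in compound 1 would leave the number where it stands.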